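The source may hold more compounds than are shown below. What is called first, only, known or untested is meant among the compounds shown, and "the series" means these compounds.

Measured in a physicochemical assay for lipophilicity; a lower number here means a more polar compound, a higher number a more lipophilic compound:
- compound 1 `CC(=O)c1ccccc1/N=N/N(C)C`: 2.19
- compound 2 `CN(C)/N=N/c1ccc(I)cc1`: 3.71

Among the measured compounds shown here, compound 2 stands at the higher of the two numbers measured so far in this assay. Its nearest neighbour is compound 1, whose value lies a good deal lower, by a gap that is beyond the usual scatter of this kind of measurement. The two compounds differ in more than one place, so their two values only show where each stands, not what any single change does.

The next compound, compound 3 `CN(C)/N=N/c1ccc(Cl)cc1`, is built from compound 2 by a single exchange: chloro in place of iodo on an aromatic carbon. In plain terms, chloro in place of iodo on an aromatic carbon. For the measured compounds named here, no pair of measured compounds shows this exchange on its own, so there is no measured step to lean on.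

For compound 3 the expectation is a modest drop in this assay, a step from compound 2 to compound 3 of about a number 0.41 log units lower from compound 2 to compound 3 (beyond the scatter), clearly beyond the scatter but not large. The estimate for compound 3 in this assay is therefore 3.3, with a likely range from 3 to 3.6.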

Compound 3, partition coefficient: 3.3
Compound 3: the middle estimate sits on the measured number at the digits printed; measured number inside the range.
By their numbers in this assay, from the lowest: compound 1; then compound 3; then compound 2.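

Among the compounds shown here, the exchange of iodo for chloro on an aromatic carbon gives a number 0.41 log units lower from compound 2 to compound 3 (beyond the scatter) in this assay, and this is the first change at a single place that can be read on its own in this set. It shows that this position, para to a group of 5 heavy atoms, responds to which of these two groups it carries: one heavy atom replaces one heavy atom, the counts of hydrogen-bond donors and acceptors stay at zero, neither group has a ring or a net charge, and still the shift is modest but real. Nothing available explains why the number moves in this direction or by this amount.

The compounds shown offer a single step at a single position, so they leave open whether the same exchange would give a similar shift on a different core, such as the core of compound 1. They also leave open how this assay would read with a different group at this position, such as an amine, a carboxylic acid or a longer chain.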